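A few compounds are considered here, and "the series" means these few. Any claim that something is new, unique, unknown or untested is made for them only; others in the source may bear on it.

Working notes on the series in a functional assay on the whole organism for inhibition, with Rattus norvegicus as the target, read by paw edema; on this read-out lower numbers stand for an effect already at smaller amounts and higher numbers for an effect only at larger amounts of compound. Compound 1 `O=C(O)c1ccc(-c2ncco2)cc1O` reaches only a limit in this assay, > 250 mg/kg. Compound 3 `O=C(O)c1ccc(-c2nccs2)cc1O` gives 110 mg/kg in this assay. Within the data shown here, the single measured step, an at least 2.2-fold lower number from compound 1 to compound 3 (0.35 log units; beyond the scatter), can be sized only from one side, since it starts from the limit of > 250 mg/kg in this assay, at which 1 of the 3 values shown sits. Compound 2 `O=C(O)c1cc(C2N=NN=N2)ccc1O` gives 110 mg/kg in this assay, level with compound 3 at the digits shown and within the scatter of it. Among the measured compounds shown here, its only other neighbour among the measured values is compound 1, which reaches only a limit.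

Compound 4 `O=C(O)c1cc(-n2cnnc2)ccc1O` is not yet measured. It differs from compound 2 by a group of 5 heavy atoms (2 carbon, 3 nitrogen; one five-membered aromatic ring with 3 hetero atoms) in place of a group of 5 heavy atoms (1 carbon, 4 nitrogen; one five-membered non-aromatic ring with 4 hetero atoms), on an aromatic carbon. For the measured compounds named here, no measured step exchanges one five-membered heterocycle for another at this place on the core; the step from compound 1 to compound 3 concerns a different pair of rings and is only a loose guide to the size such an exchange can reach. A modest shift in this assay is expected, and a step of about a 1.5-fold higher number from compound 2 to compound 4 (0.19 log units; within the scatter) is estimated, toward weaker rather than stronger, with wide uncertainty. Compound 4 is expected to give about 170 mg/kg in this assay, plausibly between 70 mg/kg and 400 mg/kg.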

Compound 4, dose for half-maximal effect: > 250 mg/kg
Compound 4: a limit, no number; the forecaster's own chance of this, stated with the estimate: 30%; middle value at least 1.4-fold (0.16 log units) from the limit.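

Replacing the five-membered non-aromatic ring with 4 hetero atoms by 4H-1,2,4-triazol-4-yl, on the aromatic carbon meta to a carboxy group and para to a hydroxy group, gives an at least 2.2-fold higher number from compound 2 to compound 4 (0.35 log units; beyond the scatter) in this assay. Among these compounds, this is the first measured ring exchange at this place, and it shows that one five-membered ring cannot simply stand in for another here, whereas the earlier step concerned a different pair of rings. Compound 4 stands at a limit and not at a number, so the step can be sized only from one side: the limit of > 250 mg/kg in this assay, at which 2 of the 4 values shown sit.

The compounds shown do not tell which counted difference between the two rings, the number of nitrogens or the aromatic ring, carries the step. On these data alone, how an amine or a carboxylic acid at this place would compare with compound 2 also stays open.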